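Swapping isopropyl for ethoxy on a weaker inhibitor

The source may hold more compounds than are shown below. What is called first, only, known or untested is meant among the compounds shown, and "the series" means these compounds.

Of the compounds shown here, three have been measured in an assay on isolated protein for inhibition of N-acylethanolamine-hydrolyzing acid amidase (Homo sapiens), read by fluorescence, with a stated time of 90 min; a higher number here means a weaker inhibitor, a lower number a stronger inhibitor. Compound 1 `COc1ccc(-c2ccc(S(=O)(=O)N[C@H]3C[C@@H](N=C=S)C3)nc2)cc1` gives 6.3 nM in this assay. Compound 2 `COc1ccc(-c2ccc(S(=O)(=O)N[C@H]3C[C@@H](N=C=S)C3)cc2)cc1F` gives 3.2 nM. Compound 3 `CC(C)c1ccc(-c2ccc(CO[C@H]3C[C@@H](N=C=S)C3)c(F)c2)cc1F`, which is built on a different linker than the other two, gives 227 nM. Among these three numbers compound 3 stands highest, and it is therefore the weakest inhibitor of the set: its gap to compound 1, the nearest of the two, lies beyond the usual scatter, and its gap to compound 2 lies further beyond it.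

The next compound, compound 4 `CCOc1ccc(-c2ccc(CO[C@H]3C[C@@H](N=C=S)C3)c(F)c2)cc1F`, is the same as compound 3 except for one change on the outer aromatic ring: ethoxy in place of isopropyl on an aromatic carbon. Among the measured compounds shown here, no pair of measured compounds shows this exact swap, so the data give no direct guide to its effect. Compounds 1 and 2 both carry a small alkoxy group on their outer ring and give low numbers, but they differ from compound 3 in other places too, so nothing firm follows from them.

The step from compound 3 to compound 4 is expected to be small, with a 1.5-fold lower number from compound 3 to compound 4 (0.18 log units; within the scatter) likely staying within the scatter. Compound 4 is expected to give about 150 nM in this assay, with a plausible range from 40 nM to 600 nM.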

Compound 4, half-maximal inhibitory concentration: 69.2 nM
Compound 4: middle estimate off by 2.2-fold (0.34 log units), on the high side; low and high end bracket the measured number.
By their numbers in this assay, from the lowest: compounds 2 and 1 (each within the scatter of the next); then compound 4; then compound 3.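

In this assay, among the compounds shown here, ethoxy in place of isopropyl gives a 3.3-fold lower number from compound 3 to compound 4 (0.52 log units; beyond the scatter), the first direct evidence that the group at this position changes the result, and a modest step that lies beyond the scatter. The two groups have the same count of 3 heavy atoms, so this change alters the make-up of the group rather than that count: ethoxy has 2 carbons and 1 oxygen, with 1 hydrogen-bond acceptor, whereas isopropyl has 3 carbons and 0 hydrogen-bond acceptors. No measurement shown here accounts for the lower number in compound 4.

This single pair cannot separate the contribution of the oxygen from that of the different chain shape, a question that an n-propyl group, with carbon only, could help to address. It also leaves open how far the trend extends to a methoxy group or a longer propoxy chain at this position, and whether the same swap would have a similar effect on the core of compound 1.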